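Swapping a Propyl for a Hydroxy on Two Related Cores

The compounds below may be only part of what the source reports. "The series", "measured", "known", "first", "only" and "open" are said of these compounds alone.

Four compounds of similar build are compared in a functional assay on NCI/ADR-RES cells (Homo sapiens) for inhibition, read by sulforhodamine B assay, with a stated time of 48 h; on this read-out lower numbers stand for stronger inhibition of growth and higher numbers for weaker inhibition of growth. Compound 1, `CCOC(=O)C1=C(C)NC(=S)NC1c1ccc(O)cc1`, gives 83.6 ug/mL. Compound 2, `CCCc1ccc(C2NC(=S)NC(C)=C2C(=O)OCC)cc1`, gives 40.3 ug/mL in this assay. Compound 3, `CCCc1ccc(C2NC(=O)NC(C)=C2C(=O)OCC)cc1`, gives 20.9 ug/mL in this assay. Compound 4, `CCOC(=O)C1=C(C)NC(=O)NC1c1ccc(O)cc1`, has not yet been measured.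

Compound 2 and compound 1 differ in one place: hydroxy in place of propyl on an aromatic carbon. This change gave a 2.1-fold higher number from compound 2 to compound 1 (0.32 log units; beyond the scatter), meaning a weakening of growth inhibition. The cores of compound 3 and compound 2 also differ, but that difference is not broken down here. The numbers for compound 3 and compound 2 lie within the usual scatter of each other, whereas compound 1 sits beyond it relative to compound 3.

Compound 4 is related to compound 3 by the same change: hydroxy in place of propyl on an aromatic carbon. The group sits in both cases on an aromatic carbon of a six-membered aromatic ring of carbon only, para to a large group, so this is the same change made on a second core. With one earlier example to go by, a step of similar size is expected, a 2.0-fold higher number from compound 3 to compound 4 (0.30 log units; within the scatter), resting on the earlier weakening seen when the propyl was replaced by hydroxy. On that basis compound 4 is expected to give around 42 ug/mL in this assay, with a likely range from 24 ug/mL to 80 ug/mL.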

Compound 4, concentration for 50% growth inhibition: 3.2 ug/mL
Estimate against measurement, compound 4: 13-fold (1.12 log units) above, outside the stated range (below it).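

In this assay, replacing propyl with hydroxy on an aromatic carbon gave a 6.5-fold lower number from compound 3 to compound 4 (0.81 log units; beyond the scatter), a clear strengthening of growth inhibition, which runs opposite to the weakening seen when the same swap was made on the other core. Set side by side, the two results show that, for this pair of cores, the outcome of the swap depends on the core that carries it, and a step measured on one core did not predict the step on the other: the same change on two cores in this assay, a 2.1-fold higher number (0.32 log units; beyond the scatter) from compound 2 to compound 1 and a 6.5-fold lower number (0.81 log units; beyond the scatter) from compound 3 to compound 4, 14-fold (1.13 log units) apart, beyond the scatter of two such steps. Two steps make no rule, however; they do not explain why the cores part ways, and they do not show which direction a third core would follow.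

The compounds shown carry only propyl or hydroxy at this place, so it remains open whether a methoxy group, an amine or a longer chain would behave like either of them on the two cores. Going by these compounds, it also remains open whether the contrast between the cores is particular to the swap of propyl for hydroxy or would appear with other groups on this aromatic ring.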